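A few compounds are considered here, and "the series" means these few. Any claim that something is new, unique, unknown or untested is made for them only; others in the source may bear on it.

Working notes on the series. Three compounds have numbers in a functional assay for inhibition of sodium/hydrogen exchanger (Oryctolagus cuniculus); a lower number here means a stronger inhibitor, a higher number a weaker inhibitor. Compound 1, `CCc1cc(Cl)c(S(C)(=O)=O)cc1C(=O)N=C(N)N`, gives in this assay 63 nM. Compound 2, `Cc1c(C(=O)N=C(N)N)cc(S(C)(=O)=O)c(Cl)c1C`, gives in this assay 58 nM. Compound 3, `CCc1cc(C)c(C(=O)N=C(N)N)cc1S(C)(=O)=O`, gives in this assay 4.8 nM, the lowest of the three numbers; its gap to compound 2 and its gap to compound 1 both lie beyond the scatter, so compound 3 is the strongest inhibitor among those measured.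

Compound 4, `CCCCCc1cc(C)c(C(=O)N=C(N)N)cc1S(C)(=O)=O`, has no number yet. Relative to compound 3 the change is propyl in place of hydrogen on a saturated chain carbon, two bonds along the chain from an aromatic carbon; the same difference, cut one bond further out, reads ethyl to pentyl. Among the measured compounds shown here, no pair of measured compounds differing in one place is available, so no step of this kind has been seen, and the direction of the change rests on expectation alone.

The expectation for compound 4 is a number close to that of compound 3, with a step from a 1.9-fold higher number from compound 3 to compound 4 (0.27 log units; within the scatter) that is estimated to be small and, if anything, towards a weaker inhibitor. Compound 4 is estimated at 9 nM, with a range from 2.5 nM to 35 nM.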

Compound 4, half-maximal inhibitory concentration: 27 nM
Estimate against measurement, compound 4: 3.0-fold (0.48 log units) below; measured number inside the range.
By their numbers in this assay, from the lowest: compound 3; then compound 4; then compounds 2 and 1 (each within the scatter of the next).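

In this assay the series now has its first step between compounds that differ in one place: propyl in place of hydrogen on a saturated chain carbon, two bonds along the chain from an aromatic carbon, gives a 5.6-fold higher number from compound 3 to compound 4 (0.75 log units; beyond the scatter) and so moves towards a weaker inhibitor. Lengthening ethyl to pentyl at this position is therefore not neutral, although this single step gives a direction for this one change and no trend with chain length. Nothing measured here bears on why the number rises.

The compounds shown leave open whether the number rises steadily with length, or whether a propyl or butyl chain in place of the ethyl would stay close to compound 3. Also open, on these data alone, is how an amine or a carboxylic acid at the end of the chain would read.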